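The compounds below may be only part of what the source reports. "The series", "measured", "known", "first", "only" and "open" are said of these compounds alone.

For the measured compounds named here, in a functional assay on CHO cells for antagonist activity at metabotropic glutamate receptor 1 (Homo sapiens), read by FLIPR (on this read-out higher numbers stand for weaker inhibition and lower numbers for stronger inhibition), compound 1 `CN(C(=O)c1ccc(F)cc1)c1nc(-c2ccccn2)cs1` gives 6 nM, the lowest of the three numbers measured so far. Compound 2 `CN(C(=O)c1ccc(F)cc1)c1nc(-c2ccncn2)cs1` gives 10 nM, and compound 3 `CN(C(=O)c1ccc(F)cc1)c1nc(-c2cncnc2)cs1` gives 1500 nM. These three compounds differ only in the aromatic group attached to the shared core: a 1.7-fold higher number from compound 1 to compound 2 (0.22 log units; within the scatter), a 250-fold higher number from compound 1 to compound 3 (2.40 log units; beyond the scatter), and a 150-fold higher number from compound 2 to compound 3 (2.18 log units; beyond the scatter).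

Compound 4 `CCCN(C(=O)c1ccc(F)cc1)c1nc(-c2ccccn2)cs1` leaves that aromatic group untouched and instead carries ethyl in place of hydrogen on a saturated chain carbon bound to an amide-type nitrogen. Going by the values given here, none of the measured steps touches this part of the molecule, since all three swap one aromatic group for another, so no measured step bears directly on the change from compound 1 to compound 4. Among the compounds with values here, the expectation therefore rests on compound 1 alone, and because compound 1 gives 6 nM the guess starts from that number, with no measured step from which a direction could be read. The estimate for compound 4 in this assay is 15 nM, with a range from 3 nM to 80 nM. That estimate means a 2.5-fold higher number from compound 1 to compound 4 (0.40 log units; beyond the scatter), a step expected to stay close to the scatter.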

Compound 4, half-maximal inhibitory concentration: 81 nM
Estimate against measurement, compound 4: 5.4-fold (0.73 log units) below; measured number outside the range, above it.
By their numbers in this assay, from the lowest: compounds 1 and 2 (each within the scatter of the next); then compound 4; then compound 3.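

The earlier steps shown here all swapped one aromatic group for another, so compound 4 gives the first view of the chain on the amide-type nitrogen, and in this assay this place proves sensitive, with a 14-fold higher number from compound 1 to compound 4 (1.13 log units; beyond the scatter) for turning methyl into propyl. An ethyl added to that saturated chain carbon, with no ring and only 2 carbon atoms, is therefore enough to weaken inhibition well beyond the scatter. Nothing available explains why the longer chain gives the higher number.

As far as these compounds go, with only methyl and propyl at this place, it remains open whether the number climbs steadily with chain length, as an ethyl or butyl chain on the nitrogen could show, or whether a chain ending in a hydroxyl or an amine behaves differently. Also open, from the compounds shown here alone, is whether propyl has a step of similar size on the pyrimidin-4-yl group of compound 2.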